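The compounds below may be only part of what the source reports. "The series", "measured", "known", "first", "only" and "open" are said of these compounds alone.

Compound 1 `CC1(C)c2cc(Cl)ccc2C(=O)N1c1cccnc1` and compound 2 `CC1c2cc(Cl)ccc2C(=O)N1c1cccnc1` share one core and differ in a single place. In an ADME assay on cells for inhibition of cytochrome P450 11B1, mitochondrial (Homo sapiens), read by HTRF (on this read-out higher numbers stand for weaker inhibition and lower numbers for stronger inhibition), compound 1 gives 4280 nM, and compound 2 gives 1250 nM. The step between them is a 3.4-fold lower number from compound 1 to compound 2 (0.53 log units; beyond the scatter), and the structural change behind it is hydrogen in place of methyl on a saturated ring carbon

Compound 3 `CC(=O)N[C@@H]1CCCc2c1cncc2N1C(=O)c2ccc(Cl)cc2[C@H]1C` is built on a different core; how that core differs from the core of compound 1 is not broken down here. In this assay, among the measured compounds shown here, compound 3 gives 5140 nM, a number that lies within the scatter of the one for compound 1 and beyond the scatter of the one for compound 2.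

Compound 4 `CC(=O)N[C@@H]1CCCc2c1cncc2N1Cc2cc(Cl)ccc2C1=O` has not yet been measured. It arises from compound 3 by hydrogen in place of methyl on a saturated ring carbon

For the measured compounds named here, this is the same kind of change as the one from compound 1 to compound 2, though not the same: in compound 1 the neighbouring ring atom bears a pyridin-3-yl group, whereas in compound 3 it bears a large group, so the surroundings of the place differ. Going by the values given here, with only one measured instance of this change, the expectation rests on a 3.4-fold lower number from compound 1 to compound 2 (0.53 log units; beyond the scatter) alone. From that, the step expected in this assay is a 3.4-fold lower number from compound 3 to compound 4 (0.53 log units; beyond the scatter). Compound 4 is therefore expected to give about 1500 nM in this assay, with a likely span from 700 nM to 3500 nM.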

Compound 4, half-maximal inhibitory concentration: 2330 nM
For compound 4 the middle estimate is 1.6-fold (0.19 log units) below the measured one, within the range that was stated.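

In this assay, hydrogen in place of methyl on a saturated ring carbon again gives a step in the same direction, a 2.2-fold lower number from compound 3 to compound 4 (0.34 log units; beyond the scatter). Set beside the earlier step, the second one shows that the change carried over from the core of compound 1 to the core of compound 3 with no size difference that can be told apart: the same change on two cores in this assay, a 3.4-fold lower number (0.53 log units; beyond the scatter) from compound 1 to compound 2 and a 2.2-fold lower number (0.34 log units; beyond the scatter) from compound 3 to compound 4, 1.6-fold (0.19 log units) apart, within the scatter of two such steps. This rests on one pair per core, however, and the two pairs are not quite alike, since one methyl stays on that carbon in compound 2 and none stays in compound 4, so the agreement shows neither that the step would hold on a further core nor why the number falls.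

The compounds shown carry only methyl or hydrogen on that saturated ring carbon, which leaves open what an ethyl, a hydroxyl or a fluorine there would do to the number. Also open, going by these compounds, is whether the step would keep its direction and size if the large group on the neighbouring ring atom ended in an amine or a carboxylic acid.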